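Exchanging the Ether Group on the Outer Aryl Ring

The source may report more compounds than this note shows. Statements on the series, on what has been measured and on what is new or still open speak of the compounds shown alone.

Measured so far in an assay for inhibition of Apoptosis regulator Bcl-2 (Homo sapiens), read by fluorescence polarization, with a stated time of 2 h; on this read-out lower numbers stand for stronger inhibition and higher numbers for weaker inhibition:
compound 1 `Cc1c(C(=O)NCCCN2CCN(C)CC2)c(-c2cccc(N3CCN(c4ccc(NS(=O)(=O)c5cccc(OC(C)C)c5)cc4)CC3)c2)c(-c2ccc(Cl)cc2)n1C` gives 2020 nM
compound 2 `Cc1c(C(=O)NCCCN2CCN(C)CC2)c(-c2cccc(N3CCN(c4ccc(NS(=O)(=O)c5cccc(OC(F)(F)F)c5)cc4)CC3)c2)c(-c2ccc(Cl)cc2)n1C` gives 763 nM

Among the measured compounds shown here, compound 2 holds the lowest of the two numbers; the step of a 2.6-fold lower number from compound 1 to compound 2 (0.42 log units; beyond the scatter) separates it from compound 1, which is the only measured step. Compound 3 `Cc1c(C(=O)NCCCN2CCN(C)CC2)c(-c2cccc(N3CCN(c4ccc(NS(=O)(=O)c5cccc(S(=O)(=O)C(F)(F)F)c5)cc4)CC3)c2)c(-c2ccc(Cl)cc2)n1C` has not yet been measured. It differs from compound 2 in one place: (trifluoromethyl)sulfonyl in place of trifluoromethoxy on an aromatic carbon. For the measured compounds named here, no measured step tests this exchange directly; the one known step, a 2.6-fold lower number from compound 1 to compound 2 (0.42 log units; beyond the scatter), concerns a different change at the same oxygen and was modest. Going by the values given here, with that as the only guide, the account expects compound 3 to land close to compound 2, and the step of a 1.3-fold lower number from compound 2 to compound 3 (0.10 log units; within the scatter) is expected to be small, quite possibly within the scatter, and if anything downward. The estimate for compound 3 is therefore 600 nM, expected to fall between 200 nM and 1800 nM.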

Compound 3, half-maximal inhibitory concentration: 153 nM
Beside the measured number, compound 3's estimate is 3.9-fold (0.59 log units) above it; measured number below the stated range.
By their numbers in this assay, from the lowest: compound 3; then compound 2; then compound 1.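

In this assay, the group on this aromatic carbon need not be attached through an oxygen, since (trifluoromethyl)sulfonyl in place of trifluoromethoxy gives a 5.0-fold lower number from compound 2 to compound 3 (0.70 log units; beyond the scatter). Taken against the isopropoxy group, the exchange gives a 13-fold lower number from compound 1 to compound 3 (1.12 log units; beyond the scatter), so compound 3 holds the lowest number of the three and the position responds far more strongly than the earlier step among the ethers alone showed. No measurement offered here accounts for this gain.

The compounds shown do not separate the contribution of the sulfonyl link from that of the trifluoromethyl on it, a question that a methylsulfonyl group on the same carbon would address. Going by these compounds, how far the trend extends also remains open, for instance to a nitrile or a carboxylic acid at this place.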